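Trimethoxyphenyl benzoxazoles: a catechol-type ring replaces the fluoro-methoxyphenyl

The compounds below may be only part of what the source reports. "The series", "measured", "known", "first", "only" and "open" are said of these compounds alone.

Measured compounds in a functional assay on U-251 cells (Homo sapiens) for antiproliferative activity, read by MTT assay, with a stated time of 48 h; a lower number here means a stronger inhibitor, a higher number a weaker inhibitor:
- compound 1 `COc1ccc(-c2nc3cccc(-c4cc(OC)c(OC)c(OC)c4)c3o2)cc1F` gives 1700 nM
- compound 2 `COc1cc(-c2cccc3nc(-c4ccc(F)cc4)oc23)cc(OC)c1OC` gives > 25000 nM, which is a limit of the assay and not a number
- compound 3 `COc1cc(-c2cccc3nc(-c4cccc(O)c4)oc23)cc(OC)c1OC` gives 5500 nM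

Compound 1 has the lowest of the two numbers shown; the nearest is compound 3, and the step of a 3.2-fold higher number from compound 1 to compound 3 (0.51 log units; beyond the scatter) lies beyond the scatter. For compound 2 the result sits at the limit of > 25000 nM in this assay, at which 1 of the 3 values shown sits, so the step of an at least 14-fold higher number from compound 1 to compound 2 (1.16 log units; beyond the scatter) can be given only as a bound.

Compound 4 `COc1cc(-c2nc3cccc(-c4cc(OC)c(OC)c(OC)c4)c3o2)ccc1O` differs from compound 1 in one place: 4-hydroxy-3-methoxyphenyl in place of 3-fluoro-4-methoxyphenyl on an aromatic carbon. Within the data shown here, two measured steps bear on this change. Removing the methoxy group altogether, as in an at least 14-fold higher number from compound 1 to compound 2 (1.16 log units; beyond the scatter), costs a great deal, and exchanging the whole ring for a 3-hydroxyphenyl, as in a 3.2-fold higher number from compound 1 to compound 3 (0.51 log units; beyond the scatter), costs a modest amount. Compound 4 keeps a methoxy group on the ring and adds a hydroxyl, so a modest weakening in this assay is expected rather than the large loss seen with compound 2.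

Compound 4 is therefore estimated at 3200 nM, within a range of 1100 nM to 10000 nM, which amounts to an expected step of a 1.9-fold higher number from compound 1 to compound 4 (0.27 log units; within the scatter).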

Compound 4, half-maximal inhibitory concentration: 10300 nM
Estimate against measurement, compound 4: 3.2-fold (0.51 log units) below; the whole stated range lies below it.
By their numbers in this assay, from the lowest: compound 1; then compounds 3 and 4 (each within the scatter of the next). At a limit, above all of these: compound 2.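

In this assay, the step of a 6.1-fold higher number from compound 1 to compound 4 (0.78 log units; beyond the scatter) shows that a methoxy group on this ring does not by itself preserve the result of compound 1, since 4-hydroxy-3-methoxyphenyl still lies clearly apart from 3-fluoro-4-methoxyphenyl at this position. Compared with the 3-hydroxyphenyl ring, the step of a 1.9-fold higher number from compound 3 to compound 4 (0.27 log units; within the scatter) gives no readable difference, so the two hydroxyl-bearing rings cannot be ordered and both stand apart from compound 1. The step of an at least 2.4-fold lower number from compound 2 to compound 4 (0.38 log units; beyond the scatter) shows that 4-hydroxy-3-methoxyphenyl gives a lower number than 4-fluorophenyl, but its size is only a bound because compound 2 sits at a limit of the assay, which is not a number: the limit of > 25000 nM in this assay, at which 1 of the 4 values shown sits.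

The compounds shown do not separate the effect of gaining the hydroxyl from that of losing the fluorine on this ring. Going by these compounds, it also remains open whether a 3-fluoro-4-hydroxyphenyl ring, or an amine or a carboxylic acid in place of the hydroxyl, would give a number closer to that of compound 1.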